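Chloro for methyl on a dihydronaphthalene ester

This account rests on a few compounds, and the source may have more. Where it says the series, first, only, none or still open, it means among the compounds named here.

The study concerns esters of a bicyclic phenol bearing an isopropyl group. Compound 1 `Cc1cc2c(C(C)C)ccc(C)c2cc1OC(=O)c1cccc(C(F)(F)F)c1` and compound 3 `Cc1cc2c(C(C)C)ccc(C)c2cc1OC(=O)c1ccc(C(F)(F)F)cc1` share a fully aromatic core and carry a trifluoromethyl group on the benzoate ring. In a functional assay on SK-LU-1 cells (Homo sapiens) for antiproliferative activity, read by sulforhodamine B assay, with a stated time of 48 h, tested at 50 uM (on this read-out lower numbers stand for less inhibition and higher numbers for more inhibition at the one concentration tested (going by the name of the read-out)), compound 1 gives 17.3%, and in the same test compound 3 gives 28.7%. Compound 2 `CC1=CC[C@H](C(C)C)c2cc(C)c(OC(=O)c3cccc(C)c3)cc21` has a partly saturated core and a 3-methylphenyl ester; in this assay compound 2 is reported as "not active" (no number reported), so no single number marks where it stands, only that it showed no appreciable effect at the one concentration tested.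

Compound 4 `CC1=CC[C@H](C(C)C)c2cc(C)c(OC(=O)c3cccc(Cl)c3)cc21` is the counterpart of compound 2 in which the change is chloro in place of methyl on an aromatic carbon. Among the measured compounds shown here, no measured pair in this set carries that same change, so the size of its step cannot be read from the data. Since compound 2 shows nothing, the expectation for compound 4 is a small step at most, within the scatter or a modest rise, not a large one in either direction. Compound 4 is therefore estimated at 12%, in a range from 0% to 35%, with a real chance that it too is simply recorded as inactive.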

Compound 4, a percentage reported as inhibition, at one concentration (the size of the read-out at that concentration, not a potency): 30.6%
Beside the measured number, compound 4's estimate is 18.6 percentage points below it; the range from low to high includes it.
By their numbers in this assay, from the lowest: compound 1; then compounds 3 and 4 (each within the scatter of the next).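

Among the compounds shown here, compound 2 has no number in this assay and only the words "not active", and no step from it to compound 4 can be read. The compounds shown leave open how large a change chloro in place of methyl brings on this core. Nothing measured here bears on the result for compound 4.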